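The source may hold more compounds than are shown below. What is called first, only, known or untested is meant among the compounds shown, and "the series" means these compounds.

Values in a functional assay on HCT-116 cells (Homo sapiens) for antiproliferative activity, with a stated time of 72 h (on this read-out higher numbers stand for weaker inhibition and lower numbers for stronger inhibition), for the measured compounds
- Compound 1 (`COc1cc(OCC(=O)NO)ccc1CNCCn1cnc2ccccc21`) gives > 10000 nM as a limit
- Compound 2 (`Cc1[nH]c2ccccc2c1C1=CCN(C(=O)c2ccc(OCC(=O)NO)cc2)CC1`) gives > 5000 nM as a limit

Compound 2 stands on a limit only, and > 5000 nM is not a number. Compound 3 (`O=C(COc1ccc(C(=O)N2CC=C(c3c[nH]c4cccc(F)c34)CC2)cc1)NO`) differs from compound 2 in one place: 4-fluoro-1H-indol-3-yl in place of 2-methyl-1H-indol-3-yl on a double-bonded ring carbon. For the measured compounds named here, no measured pair shows this change. In this assay no shift beyond the usual scatter is expected, in either direction. The expected change is a step that the limit leaves unreadable from compound 2 to compound 3 and no more. For compound 3 the estimated value is 7000 nM with an expected range from 2500 nM to 20000 nM and the assay may well report a limit again.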

Compound 3, half-maximal inhibitory concentration: 1410 nM
Estimate against measurement, compound 3: 5.0-fold (0.70 log units) above, outside the stated range (below it).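

In this assay, for the compounds shown here, 4-fluoro-1H-indol-3-yl in place of 2-methyl-1H-indol-3-yl on the double-bonded ring carbon gives an at least 3.5-fold lower number from compound 2 to compound 3 (0.54 log units; beyond the scatter), and this is the first value shown that is a number rather than a limit. Going by these compounds alone, this position therefore responds to the choice of indolyl group, which the earlier compounds could not show. Compound 2 stands on a limit, so the step gives only a minimum size: the limit of > 5000 nM in this assay, at which 1 of the 3 values shown sits.

Left open is which part of the change carries the step, the fluorine that enters or the methyl that leaves. Also open, from the compounds shown here alone, is whether chlorine or a methoxy group in the place of that fluorine would do the same.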